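The source may report more compounds than this note shows. Statements on the series, on what has been measured and on what is new or still open speak of the compounds shown alone.

Measured so far in a toxicity assay on KB cells (Homo sapiens) for cytotoxicity, read by fluorescence, with a stated time of 3 days; on this read-out lower numbers stand for an effect already at smaller amounts and higher numbers for an effect only at larger amounts of compound:
compound 1 `CCCCOC(=O)CNC(=O)[C@H](CSc1ccc([N+](=O)[O-])cc1[N+](=O)[O-])NC(=O)CC[C@H](NC(=O)c1ccccc1)C(=O)OCCCC`: > 300 uM
compound 2 `CCCCOC(=O)CNC(=O)[C@H](CSc1ccc([N+](=O)[O-])cc1[N+](=O)[O-])NC(=O)CC[C@H](NC(=O)CCC(C)C)C(=O)OCCCC`: 84 uM
compound 3 `CCCCOC(=O)CNC(=O)[C@H](CSc1ccc([N+](=O)[O-])cc1[N+](=O)[O-])NC(=O)CC[C@H](NC(=O)OC(C)(C)C)C(=O)OCCCC`: 70.4 uM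

Compound 1 gives > 300 uM, which is a limit of the assay and not a number. Among the measured compounds shown here, it is the only one of the three compounds at that limit (the limit of > 300 uM in this assay, at which 1 of the 3 values shown sits), so every step from compound 1 is a bound on its size rather than an exact size.

Compound 4 `CCCCOC(=O)CNC(=O)[C@H](CSc1ccc([N+](=O)[O-])cc1[N+](=O)[O-])NC(=O)CC[C@H](NC(=O)C(C)(C)C)C(=O)OCCCC` has not yet been measured. It has tert-butyl in place of phenyl on a carbonyl carbon, and the rest of compound 1 stays unchanged.

Two measured steps remove phenyl from the same kind of place. Isopentyl gives an at least 3.5-fold lower number from compound 1 to compound 2 (0.55 log units; beyond the scatter), and tert-butoxy gives an at least 4.2-fold lower number from compound 1 to compound 3 (0.62 log units; beyond the scatter). For the measured compounds named here, both go toward lower numbers, and no compound in this small set goes against them. The two replacements also sit close together, with a 1.2-fold lower number from compound 2 to compound 3 (0.08 log units; within the scatter). Going by the values given here, no measurement yet covers tert-butyl itself. Compound 4 is therefore expected to read like compound 2 (84 uM) and compound 3 (70.4 uM).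

The expected change in this assay is a lower number, of similar size to those two steps (an at least 3.7-fold lower number from compound 1 to compound 4 (0.57 log units; beyond the scatter)). Compound 4 is estimated at 80 uM (expected range 35 uM to 200 uM).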

Compound 4, concentration for half-maximal effect: 83.4 uM
For compound 4 the middle estimate is 1.0-fold (0.02 log units) below the measured one, within the range that was stated.
By their numbers in this assay, from the lowest: compounds 3, 4 and 2 (each within the scatter of the next). At a limit, above all of these: compound 1.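

In this assay, tert-butyl on a carbonyl carbon whose other neighbour is the amide-type nitrogen gives an at least 3.5-fold lower number from compound 1 to compound 4 (0.55 log units; beyond the scatter), so a third replacement of phenyl at this position, compact and without a ring, goes the same way as isopentyl and tert-butoxy. Tert-butyl in place of tert-butoxy gives a 1.2-fold higher number from compound 3 to compound 4 (0.07 log units; within the scatter), and tert-butyl in place of isopentyl gives a 1.0-fold lower number from compound 2 to compound 4 (0.00 log units; within the scatter), so the oxygen of tert-butoxy and the longer chain of isopentyl make no difference that can be read here, and compounds 2, 3 and 4 cannot be told apart. The step from compound 1 remains a bound and not an exact size, since the value of compound 1 is a limit: the limit of > 300 uM in this assay, at which 1 of the 4 values shown sits.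

The compounds shown leave open whether the high limit of compound 1 goes with the aromatic ring or with any ring on this carbonyl carbon, a question that cyclohexyl at the same place would address. They also leave open how a longer chain, an amine or a carboxylic acid in this position would read.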